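The compounds below may be only part of what the source reports. "The series", "measured", "known", "first", "only" and "open" are said of these compounds alone.

Measured in a functional assay on DU-145 cells (Homo sapiens) for antiproliferative activity, read by fluorescence and propidium iodide staining, with a stated time of 96 h; a lower number here means a stronger inhibitor, a higher number a weaker inhibitor:
compound 1 `O=C(Nc1cc(C(F)(F)F)cc(C(F)(F)F)c1)c1ccc(Sc2ccc(O)cc2)cc1` gives 5600 nM
compound 2 `O=C(Nc1cccc(S(F)(F)(F)(F)F)c1)c1ccc(Sc2ccc(O)cc2)cc1` gives 4350 nM
compound 3 `O=C(Nc1cc(C(F)(F)F)cc(C(F)(F)F)c1)c1ccc(S(=O)(=O)c2ccc(O)cc2)cc1` gives 9920 nM

Compound 1 and compound 2 carry different substituted anilide groups; the difference between the two cores is not broken down here, and their two values in this assay lie within the scatter of each other, so no order between them is claimed. Compound 3 is compound 1 with (4-hydroxyphenyl)sulfonyl in place of (4-hydroxyphenyl)sulfanyl on an aromatic carbon; the measured step is a 1.8-fold higher number from compound 1 to compound 3 (0.25 log units; within the scatter).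

Compound 4 `O=C(Nc1cccc(S(F)(F)(F)(F)F)c1)c1ccc(S(=O)(=O)c2ccc(O)cc2)cc1` is not yet measured. Within the data shown here, it is compound 2 with (4-hydroxyphenyl)sulfonyl in place of (4-hydroxyphenyl)sulfanyl on an aromatic carbon, the same change at the same place as the one from compound 1 to compound 3. Among the measured compounds shown here, only one measured example of this change exists, so the expectation carries that uncertainty.

The step expected in this assay is a 1.8-fold higher number from compound 2 to compound 4 (0.25 log units; within the scatter), resting on the measured step of a 1.8-fold higher number from compound 1 to compound 3 (0.25 log units; within the scatter) being repeated on the other core. Compound 4 is therefore estimated at 7800 nM, with a range expected from 4000 nM to 16000 nM.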

Compound 4, half-maximal inhibitory concentration: 6010 nM
Beside the measured number, compound 4's estimate is 1.3-fold (0.11 log units) above it, and the stated range covers the measured number.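

On the core of compound 2, (4-hydroxyphenyl)sulfonyl in place of (4-hydroxyphenyl)sulfanyl gives a 1.4-fold higher number from compound 2 to compound 4 (0.14 log units; within the scatter) in this assay. Set beside the earlier step, the change carries over from one core to the other without a detectable difference: the same change on two cores in this assay, a 1.8-fold higher number (0.25 log units; within the scatter) from compound 1 to compound 3 and a 1.4-fold higher number (0.14 log units; within the scatter) from compound 2 to compound 4, 1.3-fold (0.11 log units) apart, within the scatter of two such steps Both steps lie within the scatter, so this pair of cores shows that the change leaves the antiproliferative read-out in this assay without a clear shift, but it does not show that the sulfonyl compounds differ from their sulfanyl partners, nor that the same would hold on any core beyond these two.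

All four compounds keep the hydroxyl on the outer phenyl ring and the amide link, so an amine or a carboxylic acid in place of that hydroxyl remains an open question. Also open, going by these compounds, is how the sulfur link compares with a carbonyl or a methylene link, and whether the change behaves alike on an anilide carrying a nitrile.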